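Nitro in place of trifluoromethoxy: working notes

This account rests on a few compounds, and the source may have more. Where it says the series, first, only, none or still open, it means among the compounds named here.

In a functional assay on HO8910 cells (Homo sapiens) for inhibition, read by MTT assay, with a stated time of 24 h, tested at 1 ug/mL (a higher number here means more inhibition of growth at the concentration tested, a lower number less inhibition of growth), compound 1 (`O=C(CCCCC(S)CCS)Nc1ccccc1`) gives 6.38%, compound 2 (`O=C(CCCCC(S)CCS)Nc1ccc(F)cc1`) gives 12.2%, and compound 3 (`O=C(CCCCC(S)CCS)Nc1ccc(OC(F)(F)F)cc1`) gives 0.56%. Compound 3 cannot be separated from the unsubstituted parent, with a number 5.8 percentage points lower from compound 1 to compound 3 (within the scatter), but it does stand apart from the fluoro analogue, with a number 11.6 percentage points lower from compound 2 to compound 3 (beyond the scatter). Compound 4 (`O=C(CCCCC(S)CCS)Nc1ccc([N+](=O)[O-])cc1`) carries nitro in place of trifluoromethoxy on an aromatic carbon. Within the data shown here, no measured step involves nitro, so the closest guides are the substituent steps already seen, including a number 5.8 percentage points higher from compound 1 to compound 2 (within the scatter). Only one of them exceeds the scatter, and modestly. The expected change is a number 5.4 percentage points higher from compound 3 to compound 4 (within the scatter), not expected to exceed the scatter. For compound 4 the estimated value is 6%, with an expected range of 0% to 16%.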

Compound 4, percent growth inhibition at one concentration: 0.76%
Estimate against measurement, compound 4: 5.2 percentage points above, within the range that was stated.
By their numbers in this assay, from the lowest: compounds 3, 4, 1 and 2 (each within the scatter of the next, the first and the last beyond it).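

In this assay nitro reads like trifluoromethoxy at this place, para to a large group, with a number 0.2 percentage points higher from compound 3 to compound 4 (within the scatter) and so no separation of the two groups. Against the other two compounds nitro behaves as trifluoromethoxy did, with a number 11.4 percentage points lower from compound 2 to compound 4 (beyond the scatter) but a number 5.6 percentage points lower from compound 1 to compound 4 (within the scatter) and so fluoro now stands apart from two groups, not one. Nothing available explains this likeness.

With only a single concentration shown, it stays open whether an amine or a carboxylic acid at this place would separate from the unsubstituted parent.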